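A few compounds are considered here, and "the series" means these few. Any claim that something is new, unique, unknown or untested is made for them only; others in the source may bear on it.

Four compounds share one core in this study. Compound 1 `COc1ccc(-c2cc3nccc(-c4cc(OC)c(OC)c(OC)c4)n3n2)cc1N` gives 251 nM in a functional assay on HCT-116 cells (Homo sapiens) for inhibition, read by CCK-8 assay, with a stated time of 48 h; a higher number here means a weaker inhibitor, a lower number a stronger inhibitor. Compound 2 `COc1cc(-c2ccnc3cc(-c4ccc5cc[nH]c5c4)nn23)cc(OC)c1OC` gives 187 nM in this assay, and the step of a 1.3-fold lower number from compound 1 to compound 2 (0.13 log units; within the scatter) shows that the two numbers sit within the usual scatter of each other. Compound 3 `COc1cc(-c2ccnc3c(-c4ccc(C)cc4)cnn23)cc(OC)c1OC` gives only a limit in this assay, > 10000 nM. Compound 4 `COc1ccc(-c2cc3nccc(-c4cc(OC)c(OC)c(OC)c4)n3n2)cc1F` has not been measured; it differs from compound 2 by 3-fluoro-4-methoxyphenyl in place of 1H-indol-6-yl on an aromatic carbon. Within the data shown here, the one measured step at this position, a 1.3-fold lower number from compound 1 to compound 2 (0.13 log units; within the scatter), was small, so no change beyond the scatter is expected for the step of a 1.4-fold higher number from compound 2 to compound 4 (0.14 log units; within the scatter). Compound 4 is therefore expected to give about 260 nM in this assay, between 110 nM and 650 nM.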

Compound 4, half-maximal inhibitory concentration: 2840 nM
Compound 4: middle estimate off by 11-fold (1.04 log units), on the low side, outside the stated range (above it).
By their numbers in this assay, from the lowest: compounds 2 and 1 (each within the scatter of the next); then compound 4. At a limit, above all of these: compound 3.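

The position on this aromatic carbon is not indifferent to its group, as the earlier pair within the scatter might have implied: there is a 15-fold higher number from compound 2 to compound 4 (1.18 log units; beyond the scatter) when 3-fluoro-4-methoxyphenyl enters in place of 1H-indol-6-yl. The change narrows to one substituent on the phenyl ring, with an 11-fold higher number from compound 1 to compound 4 (1.05 log units; beyond the scatter) for fluoro in place of amino. No measurement shown bears on the reason for this rise. Going by these compounds, whether a hydroxyl or a methylamino group in place of the amino would keep the number of compound 1 remains open.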